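A Dichlorophenyl Variant Estimated Before Its Measurement

This account rests on a few compounds, and the source may have more. Where it says the series, first, only, none or still open, it means among the compounds named here.

In a functional assay on HepG2 cells (Homo sapiens) for antiproliferative activity, read by MTT assay, with a stated time of 48 h (on this read-out higher numbers stand for weaker inhibition and lower numbers for stronger inhibition), the three measured compounds read as follows:
compound 1 `Cc1cccc(NC(=O)Nc2cccc(CNc3nccnc3Cl)c2)c1`, 11200 nM
compound 2 `Cc1ccc(NC(=O)Nc2cccc(CNc3nccnc3Cl)c2)cc1C`, 10700 nM
compound 3 `O=C(Nc1cccc(CNc2nccnc2Cl)c1)Nc1cccc(C(F)(F)F)c1`, 6210 nM

Compound 1 is the starting point, and neither measured step away from it leaves the scatter: a 1.0-fold lower number from compound 1 to compound 2 (0.02 log units; within the scatter), a 1.8-fold lower number from compound 1 to compound 3 (0.26 log units; within the scatter). Compound 4 `O=C(Nc1cccc(CNc2nccnc2Cl)c1)Nc1ccc(Cl)c(Cl)c1` has not yet been measured; it differs from compound 1 by 3,4-dichlorophenyl in place of 3-methylphenyl on an amide-type nitrogen. Among the compounds with values here, the nearest precedent is the step to compound 3, where trifluoromethyl replaced methyl on an aromatic carbon and the number moved only a little. For compound 4 a similarly modest step toward a lower number is expected, a 1.6-fold lower number from compound 1 to compound 4 (0.20 log units; within the scatter). Compound 4 is therefore estimated at 7000 nM, between 3500 nM and 14000 nM.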

Compound 4, half-maximal inhibitory concentration: 6170 nM
The estimate for compound 4 lay 1.1-fold (0.05 log units) above the measured number, and the stated range covers the measured number.
By their numbers in this assay, from the lowest: compounds 4, 3, 2 and 1 (each within the scatter of the next).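

In this assay the 3,4-dichlorophenyl group shows a 1.8-fold lower number from compound 1 to compound 4 (0.26 log units; within the scatter) and a 1.7-fold lower number from compound 2 to compound 4 (0.24 log units; within the scatter). The amide-type nitrogen thus carries a ring with two chlorines as well as rings with methyl or trifluoromethyl, and each of these steps stays within the scatter. Nothing at hand explains why these rings read so alike.

The compounds shown leave open whether a ring carrying a methoxy group, an amine or a carboxylic acid would stay in this range. They also leave open how changes to the shared core would read.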